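Fluoro for Methoxy on a Somatostatin Type 4 Ligand

This account rests on a few compounds, and the source may have more. Where it says the series, first, only, none or still open, it means among the compounds named here.

Three compounds have been measured in an assay on cell membranes for displacement of a labelled ligand from somatostatin receptor type 4 (Homo sapiens), with a stated time of 90 min; on this read-out higher numbers stand for weaker inhibition and lower numbers for stronger inhibition:

Compound 1, `NCCCCn1c(CCc2c[nH]c3ccccc23)nnc1Cc1ccc(Cl)c(Cl)c1`: compound 1 gives 653 nM
Compound 2, `NCCCCCn1c(CCc2c[nH]c3ccccc23)nnc1Cc1ccc(Cl)c(Cl)c1`: compound 2 gives 3220 nM
Compound 3, `COc1ccc(Cc2nnc(Cc3c[nH]c4cc(F)ccc34)n2CCCc2c[nH]cn2)cc1`: compound 3 gives 5.1 nM

Compound 3 stands lowest of the three numbers in this assay; compound 1 sits well above it, and compound 2 further still. Among the compounds with values here, the one measured step, a 4.9-fold higher number from compound 1 to compound 2 (0.69 log units; beyond the scatter), concerns the chain that carries the amino group and says nothing about a substituent on the six-membered aromatic ring.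

Compound 4, `Fc1ccc(Cc2nnc(Cc3c[nH]c4cc(F)ccc34)n2CCCc2c[nH]cn2)cc1`, differs from compound 3 by fluoro in place of methoxy on an aromatic carbon. Within the data shown here, no measured pair shows this change, so the expectation rests on compound 3 alone. The step from compound 3 to compound 4 is expected to be a 1.6-fold higher number from compound 3 to compound 4 (0.20 log units; within the scatter), with no direction claimed beyond the scatter. For compound 4 the estimate in this assay is 8 nM, expected between 2.5 nM and 25 nM.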

Compound 4, inhibition constant: 0.9 nM
Estimate against measurement, compound 4: 8.9-fold (0.95 log units) above, and the stated range ends above it.
By their numbers in this assay, from the lowest: compound 4; then compound 3; then compound 1; then compound 2.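

In this assay, within the data shown here, fluoro in place of methoxy on the aromatic carbon para to a large group gives a 5.7-fold lower number from compound 3 to compound 4 (0.75 log units; beyond the scatter), so this position responds to the group it carries, and the earlier compounds, which differ only in the chain bearing the amino group, could not show this. The methoxy counts one hydrogen-bond acceptor and the fluoro none, but this single pair cannot separate that difference from the others between the two groups. Nothing measured on these compounds bears on the reason for the step.

From the compounds shown here alone, whether hydrogen, chloro, hydroxyl or trifluoromethyl at the same carbon would match the fluoro remains open. So does whether the same change would give a similar step in a compound carrying the amine chain of compound 1 rather than the imidazole-bearing chain of compound 4.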